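Growing the Ring on the Urea Nitrogen

This account rests on a few compounds, and the source may have more. Where it says the series, first, only, none or still open, it means among the compounds named here.

Two compounds share one core and differ only in the ring carried by the urea carbonyl. In an assay on HEK293 cells for displacement of a labelled ligand from melanin-concentrating hormone receptor 1 (Homo sapiens) (on this read-out higher numbers stand for weaker inhibition and lower numbers for stronger inhibition), compound 1 `O=C(NC1CCN(Cc2ccn(-c3ccc(C(F)(F)F)cc3)c2)CC1)N1CCC(c2ccccc2O)CC1` gives 36 nM, and compound 2 `O=C(NC1CCN(Cc2ccn(-c3ccc(C(F)(F)F)cc3)c2)CC1)N1CC[C@@H](O)C1` gives 138 nM, the higher of the two numbers. Compound 3 `O=C(NC1CCN(Cc2ccn(-c3ccc(C(F)(F)F)cc3)c2)CC1)N1CCCCC1CCO` carries 2-(2-hydroxyethyl)piperidin-1-yl in place of 3-hydroxypyrrolidin-1-yl on a carbonyl carbon. Within the data shown here, no measured pair covers this change. Since the larger ring of compound 1 gave 36 nM, a modest gain is expected: a step of a 1.7-fold lower number from compound 2 to compound 3 (0.24 log units; within the scatter) from compound 2 to compound 3 toward a lower number, though it may stay within the scatter. Compound 3 is estimated at 80 nM, between 30 nM and 250 nM.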

Compound 3, half-maximal inhibitory concentration: 39 nM
Beside the measured number, compound 3's estimate is 2.1-fold (0.31 log units) above it; the measured number falls inside the stated range.
By their numbers in this assay, from the lowest: compounds 1 and 3 (each within the scatter of the next); then compound 2.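

Replacing 3-hydroxypyrrolidin-1-yl with 2-(2-hydroxyethyl)piperidin-1-yl on a carbonyl carbon gives a 3.5-fold lower number from compound 2 to compound 3 (0.55 log units; beyond the scatter), the first step showing that the number responds to a change at this position. The two groups have the same hydrogen-bond donor and acceptor counts, so this step comes without any change in those counts. No measurement here explains the step.

Ring size and chain change together, so their contributions cannot be separated. On these data alone, whether the hydroxyl matters also stays open, and 2-ethylpiperidin-1-yl or a chain ending in an amine would address that.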